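Adding a chloro group to compound 1 at the limit

The source may hold more compounds than are shown below. What is called first, only, known or untested is meant among the compounds shown, and "the series" means these compounds.

Compound 1 `Fc1ccc(NC(=S)Nc2nc3ccccc3s2)cc1` is known only through a limit. In a functional assay on B16-F10 cells (Mus musculus) for cytotoxicity, read by MTT assay, with a stated time of 48 h (a lower number here means a stronger inhibitor, a higher number a weaker inhibitor), compound 1 gives > 50000 nM, which is a limit of the measurement. Compound 2 `S=C(Nc1ccccc1)Nc1nc2ccccc2s1` gives > 50000 nM in this assay, again a limit. Compound 3 `Cc1ccc2nc(NC(=S)Nc3ccc(F)cc3)sc2c1` gives > 50000 nM in this assay, also a limit. The step that the two limits leave unreadable from compound 1 to compound 2 and the step that the two limits leave unreadable from compound 1 to compound 3 thus have no readable size, since all three values sit at the limit of > 50000 nM in this assay, at which 3 of the 3 values shown sit. Compound 4 `Fc1ccc(NC(=S)Nc2nc3c(Cl)cccc3s2)cc1` differs from compound 1 by chloro in place of hydrogen on an aromatic carbon, placed ortho to a fused ring. Among the compounds with values here, no measured step around this core has a readable size, so no direction beyond the scatter can be read from them. Compound 4 is therefore expected to stay at the limit, estimated at 50000 nM with a range from 15000 nM to 200000 nM. The expected step is a number no higher from compound 1 to compound 4 (the limit leaves the size open).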

Compound 4, half-maximal inhibitory concentration: > 50000 nM
Compound 4 was reported as a limit (the forecaster's own chance of this, stated with the estimate: 80%); the middle value lies on the limit itself.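

No step can be read between compound 1 and compound 4, since both stand at a limit in this assay: the limit of > 50000 nM in this assay, at which 4 of the 4 values shown sit.

The compounds shown leave open whether the chloro, fluoro or methyl group changes the value at all.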